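Same Side-Chain Swap, Now on the Free Acid

The source may report more compounds than this note shows. Statements on the series, on what has been measured and on what is new or still open speak of the compounds shown alone.

Compound 1 `C[C@@H](O)[C@H](NC(=O)CN(c1nc(Cl)nc2[nH]cnc12)C1CC1)C(=O)OCc1ccccc1` is a benzyl ester built on a shared core. In a functional assay on the whole organism (Tail, strain ICR) with Mus musculus as the target, in the tail flick test, with a stated time of 30 min, at a dose of 25 umol/kg by the oral route (a lower number here means a weaker effect, a higher number a stronger effect of the compound at the dose given), compound 1 gives 21.9%. Compound 2 `NCCCC[C@H](NC(=O)CN(c1nc(Cl)nc2[nH]cnc12)C1CC1)C(=O)OCc1ccccc1` differs from it only by 4-aminobutyl in place of 1-hydroxyethyl on a saturated chain carbon bound to an amide-type nitrogen and a carbonyl carbon; in this assay compound 2 gives 26.1%, so the step is a number 4.2 percentage points higher from compound 1 to compound 2 (within the scatter). Compound 3 `C[C@@H](O)[C@H](NC(=O)CN(c1nc(Cl)nc2[nH]cnc12)C1CC1)C(=O)O` keeps the side chain of compound 1, and its core differs from that of compound 1 by hydrogen in place of benzyl on an oxygen next to a carbonyl group. In this assay compound 3 gives 18.6%, which makes the step of a number 3.3 percentage points lower from compound 1 to compound 3 (within the scatter). All three measured numbers therefore sit close to one another, with none of the gaps beyond the usual scatter.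

Compound 4 `NCCCC[C@H](NC(=O)CN(c1nc(Cl)nc2[nH]cnc12)C1CC1)C(=O)O` has not yet been measured. Among the compounds with values here, it stands to compound 3 exactly as compound 2 stands to compound 1: the difference is 4-aminobutyl in place of 1-hydroxyethyl on a saturated chain carbon bound to an amide-type nitrogen and a carbonyl carbon, the same change at the same place, the only other difference being the core, which is the one already described between compound 1 and compound 3. Within the data shown here, the expected step for compound 4 is a number 4.4 percentage points higher from compound 3 to compound 4 (within the scatter), because the one earlier instance of this change gave a number 4.2 percentage points higher from compound 1 to compound 2 (within the scatter). Among the measured compounds shown here, on that single precedent, compound 4 is expected to give about 23% in this assay, with a plausible span from 12% to 34%; with only one prior example and a step inside the scatter, this estimate is held loosely.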

Compound 4, a percentage reported as activity, at one dose (the size of the read-out at that dose, not a potency): 31.2%
Estimate against measurement, compound 4: 8.2 percentage points below, within the range that was stated.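

In this assay, 4-aminobutyl in place of 1-hydroxyethyl on the free acid gives a number 12.6 percentage points higher from compound 3 to compound 4 (beyond the scatter), a step that clears the usual scatter, while the same swap on the benzyl ester does not; even so, the two steps cannot be told apart, so the side-chain change carries across the two cores as far as these numbers can show: the same change on two cores in this assay, a number 4.2 percentage points higher (within the scatter) from compound 1 to compound 2 and a number 12.6 percentage points higher (beyond the scatter) from compound 3 to compound 4, 8.4 percentage points apart, within the scatter of two such steps. Hydrogen in place of benzyl on the compounds with the 4-aminobutyl side chain gives a number 5.1 percentage points higher from compound 2 to compound 4 (within the scatter), and this change also reads alike on both side chains: the same change on two cores in this assay, a number 3.3 percentage points lower (within the scatter) from compound 1 to compound 3 and a number 5.1 percentage points higher (within the scatter) from compound 2 to compound 4, 8.4 percentage points apart, within the scatter of two such steps. This does not show that the swap works better on the free acid than on the ester, and since both comparisons rest on the same four compounds, it says nothing about how the change would behave on any other core.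

The compounds shown leave open whether the step follows the amine at the end of the 4-aminobutyl group or the length of the chain, which a plain butyl group or a shorter aminoethyl group at the same place could help to separate. Also open, on these data alone, is whether the side-chain change would carry over to a different ester, such as a methyl ester, or to a primary amide in place of the carboxylic acid.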